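The compounds below may be only part of what the source reports. "The series", "measured", "known", "first", "only" and "open" are said of these compounds alone.

Three compounds share one core and differ only in the ring attached to an aromatic nitrogen. Compound 1 `CC1(C)[C@H]2CC[C@]1(C)N(Cc1cn(-c3ccccc3O)nn1)C(=O)C2` gives 410 nM in a functional assay on SGC-7901 cells (Homo sapiens) for inhibition, read by MTT assay, with a stated time of 24 h; a lower number here means a stronger inhibitor, a higher number a weaker inhibitor. Compound 2 `Cc1ccc(-n2cc(CN3C(=O)C[C@@H]4CC[C@@]3(C)C4(C)C)nn2)cc1` gives 390 nM in this assay. Compound 3 `CC1(C)[C@H]2CC[C@]1(C)N(Cc1cn(-c3ccc(F)cc3)nn1)C(=O)C2` gives 500 nM in this assay, the highest of the three numbers, though every step leading to it lies within the scatter. The steps are small throughout: a 1.1-fold lower number from compound 1 to compound 2 (0.02 log units; within the scatter), a 1.2-fold higher number from compound 1 to compound 3 (0.09 log units; within the scatter) and a 1.3-fold higher number from compound 2 to compound 3 (0.11 log units; within the scatter). Compound 4 `CC1(C)[C@H]2CC[C@]1(C)N(Cc1cn(-c3cccc(Br)c3)nn1)C(=O)C2` has not yet been measured; it differs from compound 3 by 3-bromophenyl in place of 4-fluorophenyl on an aromatic nitrogen. All three measured steps exchange one such ring for another at this same place, and none moved the number beyond the scatter, so for the step to compound 4 no change beyond the scatter is expected in this assay. Compound 4 is therefore estimated at 500 nM, with a range from 250 nM to 1000 nM. That estimate means no change at the digits printed from compound 3 to compound 4 (within the scatter), which is expected to stay inside the scatter.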

Compound 4, half-maximal inhibitory concentration: 120 nM
For compound 4 the middle estimate is 4.2-fold (0.62 log units) above the measured one; measured number outside the range, below it.
By their numbers in this assay, from the lowest: compound 4; then compounds 2, 1 and 3 (each within the scatter of the next).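

This position is not indifferent to the ring it carries. Going by these compounds alone, the exchanges among 2-hydroxyphenyl, 4-methylphenyl and 4-fluorophenyl all stayed within the scatter, but in this assay 3-bromophenyl gives a 4.2-fold lower number from compound 3 to compound 4 (0.62 log units; beyond the scatter), along with a 3.3-fold lower number from compound 2 to compound 4 (0.51 log units; beyond the scatter) and a 3.4-fold lower number from compound 1 to compound 4 (0.53 log units; beyond the scatter), so it is the first ring here that moves the number beyond the scatter, even though 3-bromophenyl and 4-fluorophenyl match in every count of heavy atoms, donors and acceptors. Nothing measured here explains why this ring gives the stronger inhibitor.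

The change alters both the halogen and its place on the ring, so the compounds shown cannot separate the two; 4-bromophenyl and 3-fluorophenyl would do that. From the compounds shown here alone, how a phenyl ring bearing an amine or a carboxylic acid would behave at this position also stays open.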